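The source may report more compounds than this note shows. Statements on the series, on what has been measured and on what is new or still open speak of the compounds shown alone.

The study covers three compounds built on one shared core. Going by the values given here, compound 1 `COc1ccc(OC)c(/C=C/c2nnc(Nc3ccc(Cl)cc3)o2)c1` is the only member that returns a number: in a functional assay on TK-10 cells (Homo sapiens) for antiproliferative activity, read by sulforhodamine B assay, with a stated time of 48 h (on this read-out lower numbers stand for stronger inhibition of growth and higher numbers for weaker inhibition of growth), compound 1 gives 83200 nM. Compound 2 `COc1ccc(OC)c(/C=C/C(=O)N/N=C/c2ccc(Cl)cc2)c1` is the second measured member. In this assay compound 2 reaches only a limit of the measurement, not a number, reported as > 100000 nM. This is the limit of > 100000 nM in this assay, at which 1 of the 2 values shown sits, so where compound 2 lies relative to compound 1 cannot be read from the numbers shown. Compound 3 `COc1ccc(OC)c(/C=C/C(=O)N/N=C/c2ccccc2)c1` is yet to be measured and differs from compound 2 in one place: hydrogen in place of chloro on an aromatic carbon, the 4-chlorophenyl becoming phenyl. Among the compounds with values here, no measured step of this kind exists in the set to draw on. Compound 3 is therefore expected to show a step that the limit leaves unreadable from compound 2 to compound 3 that stays within the scatter, most likely ending again at the limit. Compound 3 is estimated at 120000 nM, with a range from 50000 nM to 300000 nM.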

Compound 3, concentration for total growth inhibition: > 100000 nM
Compound 3 gave a limit, no number; the forecaster's own chance of this, stated with the estimate: 70%; the middle value does not contradict the limit.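

Compound 2 and compound 3 both stop at a limit of this assay, not at a number, so no step between them can be read: the limit of > 100000 nM in this assay, at which 2 of the 3 values shown sit.

The compounds shown leave open what the change from 4-chlorophenyl to phenyl does to growth inhibition.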